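Amide variation on the shared core

The source may report more compounds than this note shows. Statements on the series, on what has been measured and on what is new or still open speak of the compounds shown alone.

Compound 1 `CN1CCc2nc(C#Cc3ccccc3)sc2C1` gives 34 nM in an assay on HEK293 cells for positive allosteric modulation of metabotropic glutamate receptor 5 (Homo sapiens), read by FLIPR, with a stated time of 1 h; on this read-out lower numbers stand for an effect already at smaller amounts and higher numbers for an effect only at larger amounts of compound. Compound 2 `COC1CC(C(=O)N2CCc3nc(C#Cc4ccccc4)sc3C2)C1` gives 640 nM, and the step of a 19-fold higher number from compound 1 to compound 2 (1.27 log units; beyond the scatter). Compound 3 `Cc1cccc(C(=O)N2CCc3nc(C#Cc4ccccc4)sc3C2)n1` gives 160 nM, the second highest of the three numbers; the step of a 4.0-fold lower number from compound 2 to compound 3 (0.60 log units; beyond the scatter), while compound 1 sits lower still. Compound 4 `O=C(N1CCCC1)N1CCc2nc(C#Cc3ccccc3)sc2C1` differs from compound 3 in one place: pyrrolidin-1-yl in place of 6-methylpyridin-2-yl on a carbonyl carbon. Both measured steps bear on this position, the large one running toward higher numbers and the modest one back toward lower. Compound 4 carries neither the methyl of compound 1 nor the aromatic ring of compound 3, so its nearest measured neighbour is compound 2. Compound 4 is therefore expected to give 400 nM (range 130 nM to 1300 nM), an estimated step of a 2.5-fold higher number from compound 3 to compound 4 (0.40 log units; beyond the scatter) toward a higher number.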

Compound 4, half-maximal effective concentration: 9.8 nM
Compound 4: middle estimate off by 41-fold (1.61 log units), on the high side; measured number below the stated range.
By their numbers in this assay, from the lowest: compound 4; then compound 1; then compound 3; then compound 2.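

In this assay, a carbonyl-bearing group in place of methyl on the ring amine nitrogen does not have to raise the number (a 3.5-fold lower number from compound 1 to compound 4 (0.54 log units; beyond the scatter)). The outcome rests on the group on the carbonyl carbon, as pyrrolidin-1-yl gives the lowest number of the series (a 16-fold lower number from compound 3 to compound 4 (1.21 log units; beyond the scatter); a 65-fold lower number from compound 2 to compound 4 (1.81 log units; beyond the scatter)). Nothing available accounts for this change.

Going by these compounds, whether piperidin-1-yl or an open-chain dimethylamino group on that carbonyl carbon holds the low number stays open. Whether the ring nitrogen of pyrrolidin-1-yl, rather than the ring as a whole, drives the change also remains unresolved.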